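The compounds below may be only part of what the source reports. "The series", "measured", "known", "first", "only" and "open" are said of these compounds alone.

Measured so far in a functional assay on NCI-H460 cells (Homo sapiens) for cytotoxicity, read by MTT assay, with a stated time of 72 h; a higher number here means a weaker inhibitor, a lower number a stronger inhibitor: compound 1 `CN(C)CCCNc1nc(-c2ccc(NC(=O)Nc3ccc(F)cc3)cc2)nc2c(Cl)c(Cl)sc12` gives 650 nM; compound 2 `CN(C)CCCNc1nc(-c2ccc(NC(=O)Nc3ccc(Cl)cc3)cc2)nc2c(Cl)c(Cl)sc12` gives 230 nM; compound 3 `CN(C)CCCNc1nc(-c2ccc(NC(=O)Nc3ccccc3Cl)cc2)nc2c(Cl)c(Cl)sc12` gives 490 nM.

Compound 3 holds the second highest of the three numbers; the step of a 1.3-fold lower number from compound 1 to compound 3 (0.12 log units; within the scatter) is within the scatter, while a 2.1-fold higher number from compound 2 to compound 3 (0.33 log units; beyond the scatter) is beyond it. Compound 4 `CN(C)CCCNc1nc(-c2ccc(NC(=O)Nc3ccc(Cl)cc3Cl)cc2)nc2c(Cl)c(Cl)sc12` differs from compound 3 by chloro in place of hydrogen on an aromatic carbon. For the measured compounds named here, the one step that bears on this is a 2.8-fold lower number from compound 1 to compound 2 (0.45 log units; beyond the scatter), where the same chloro on the para position produced a modest gain, and compound 2, carrying that chloro, gives the lowest number here. A modest lowering, a 1.9-fold lower number from compound 3 to compound 4 (0.28 log units; within the scatter), is therefore expected for compound 4. Compound 4 is estimated at 260 nM, with a range of 110 nM to 600 nM.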

Compound 4, half-maximal inhibitory concentration: 980 nM
For compound 4 the middle estimate is 3.8-fold (0.58 log units) below the measured one, outside the stated range (above it).
By their numbers in this assay, from the lowest: compound 2; then compounds 3, 1 and 4 (each within the scatter of the next).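

In this assay, the gain seen with chloro on the 4-chlorophenyl of compound 2 does not survive a second chloro, since the 2,4-dichlorophenyl of compound 4 reads worse (a step of a 4.3-fold higher number from compound 2 to compound 4 (0.63 log units; beyond the scatter)). Placed para to a large group and meta to a chloro group, this chloro brings no readable gain over the 2-chlorophenyl (a step of a 2.0-fold higher number from compound 3 to compound 4 (0.30 log units; within the scatter)), and the 4-fluorophenyl comparison is equally unresolved (a step of a 1.5-fold higher number from compound 1 to compound 4 (0.18 log units; within the scatter)). No available evidence accounts for this.

From the compounds shown here alone, whether methoxy or an amine at this position would behave like chloro remains open.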